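This account rests on a few compounds, and the source may have more. Where it says the series, first, only, none or still open, it means among the compounds named here.

Of the compounds shown here, three have so far been measured in a physicochemical assay for lipophilicity, in phosphate buffer, measured as octanol-water partition, at pH 11.5; a higher number here means a more lipophilic compound, a lower number a more polar compound. Compound 2 (`CCCCCCCCOC(=N)NC(=N)Nc1ccc(Cl)cc1`) gives 5.32 and stands highest of the three. Compound 1 (`CCCCOC(=N)NC(=N)Nc1ccc(Cl)cc1`) gives 3.32 and lies beyond the scatter under it. Compound 3 (`CCCS(=O)(=O)c1ccc(NC(=N)NC(=N)NCCCCCCNC(=N)NC(=N)Nc2ccc(S(=O)(=O)CCC)cc2)cc1`) gives 2.1 and lies furthest under it.

The next compound is compound 4 (`CCOC(=N)NC(=N)Nc1ccc(Cl)cc1`). The change from compound 2 is hydrogen in place of hexyl on a saturated chain carbon, two bonds along the chain from an oxygen on an unsaturated carbon and amounts to hydrogen in place of hexyl on a saturated chain carbon, two bonds along the chain from an oxygen on an unsaturated carbon. For the measured compounds named here, one measured step bears on this change: a number 2.00 log units higher from compound 1 to compound 2 (beyond the scatter) when butyl takes the place of hydrogen on that chain. Going by the values given here, this large step is the only guide, and compound 3 offers no comparable step. Here the longer hexyl leaves rather than enters, so a fall larger than that step is expected in this assay on this evidence. The expected change is a number 3.02 log units lower from compound 2 to compound 4 (beyond the scatter) and rests on that single step. For compound 4 the estimated value is 2.3 within an expected range of 1.9 to 2.7 on present evidence.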

Compound 4, partition coefficient: 2.32
Compound 4: middle estimate off by 0.02 log units, on the low side; the measured number falls inside the stated range.
By their numbers in this assay, from the lowest: compounds 3 and 4 (each within the scatter of the next); then compound 1; then compound 2.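

The chain on this oxygen can now be read at three lengths in this assay: hydrogen in place of hexyl gives a number 3.00 log units lower from compound 2 to compound 4 (beyond the scatter) and hydrogen in place of ethyl gives a number 1.00 log units lower from compound 1 to compound 4 (beyond the scatter). Together with a number 2.00 log units higher from compound 1 to compound 2 (beyond the scatter), these steps show the number rising at each lengthening from compound 4 through compound 1 to compound 2, with no compound in this series going against that order, and the step is larger where the group exchanged is larger. Nothing available explains why the number follows the chain in this way.

On these data alone, whether a branched chain, a cyclohexyl ring or a chain ending in a hydroxyl or an amine would follow the same order remains open. So does whether a chain longer than that of compound 2 would extend it.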